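This account rests on a few compounds, and the source may have more. Where it says the series, first, only, none or still open, it means among the compounds named here.

compound 1 `c1ccc(COc2cc(-c3ccccc3)nc3ccccc23)cc1`: > 10 ug/mL
compound 2 `COc1ccc2nc(-c3ccccc3)cc(O)c2c1`: 0.33 ug/mL
compound 3 `CC(C)COc1cc(-c2ccccc2)nc2ccccc12`: not yet measured

In a functional assay on P388 cells (Mus musculus) for cytotoxicity (a higher number here means that more compound is needed for the effect, a lower number that less compound is needed), compound 1 gives only a limit, > 10 ug/mL, and not an exact number. Compound 2 gives a true number, 0.33 ug/mL. The step of interest leads from compound 1 to compound 3, where benzyloxy gives way to isobutoxy. This places isopropyl in place of phenyl on a saturated chain carbon bound to an oxygen on an aromatic ring. The rest of the core of compound 1 stays the same. Within the data shown here, no pair of measured compounds shows what such a swap does in this assay, so no clear shift in either direction can be predicted. The expected step, an at least 1.2-fold lower number from compound 1 to compound 3 (0.09 log units; that floor lies within the scatter), is none beyond the usual scatter. Compound 3 is estimated at 8 ug/mL, with an expected range from 2.5 ug/mL to 20 ug/mL. A result reported only as a limit would also be no surprise.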

Compound 3, half-maximal effective concentration: > 10 ug/mL
Compound 3 was reported as a limit; the forecaster's own chance of this, stated with the estimate: 50%; at least 1.2-fold (0.09 log units) between middle value and limit.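

In this assay compound 1 gives > 10 ug/mL, which is a limit and not a number. Among these compounds, compound 3 gives > 10 ug/mL, again a limit, so no step between compound 1 and compound 3 can be read. The compounds shown leave open whether benzyloxy and isobutoxy differ at all in this assay.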